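A Fluorine on the Bridging Carbon of Compound 2

The source may report more compounds than this note shows. Statements on the series, on what has been measured and on what is new or still open speak of the compounds shown alone.

Of the compounds shown here, two with a shared core have been measured. Compound 1 `C=C(c1ccccc1)c1cccc(N(Cc2cccnc2)S(=O)(=O)CC)c1` gives 200 nM in an assay on isolated protein with metabotropic glutamate receptor 2 (Homo sapiens) as the target (on this read-out lower numbers stand for an effect already at smaller amounts and higher numbers for an effect only at larger amounts of compound), and compound 2 `CCS(=O)(=O)N(Cc1cccnc1)c1cccc(Cc2ccccc2)c1` gives 310 nM in this assay. Of these two numbers compound 2 carries the higher one, yet the step of a 1.6-fold higher number from compound 1 to compound 2 (0.19 log units; within the scatter), with benzyl in place of 1-phenylethenyl on an aromatic carbon, lies within the scatter, so the two compounds cannot be separated. Compound 3 `CCS(=O)(=O)N(Cc1cccnc1)c1cccc(C(F)c2ccccc2)c1` has not been measured; it differs from compound 2 by fluoro in place of hydrogen on a saturated chain carbon bound to two aromatic carbons. Going by the values given here, no measured step touches this saturated carbon, and the single known step was within the scatter, so nothing in the data points in either direction. The expected step is therefore a 1.0-fold lower number from compound 2 to compound 3 (0.01 log units; within the scatter) in this assay, no change beyond the scatter. The estimate for compound 3 is 300 nM, with a range from 120 nM to 800 nM.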

Compound 3, half-maximal effective concentration: 180 nM
Compound 3: the middle estimate sits 1.7-fold (0.22 log units) above what was measured; the range from low to high includes it.
By their numbers in this assay, from the lowest: compounds 3, 1 and 2 (each within the scatter of the next).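

In this assay, the saturated chain carbon bound to two aromatic carbons now has a measured step of its own, with fluoro in place of hydrogen (a 1.7-fold lower number from compound 2 to compound 3 (0.24 log units; within the scatter)). This position therefore takes a single fluorine without a change that can be told apart from the scatter, which the earlier pair, with its change of benzyl to 1-phenylethenyl, could not show. The step with fluoro(phenyl)methyl in place of 1-phenylethenyl (a 1.1-fold lower number from compound 1 to compound 3 (0.05 log units; within the scatter)) also stays within the scatter, so the three groups on this aromatic carbon cannot be separated. No independent measurement is available to explain these results.

Still open, on these data alone, is whether a hydroxyl group, a methyl group or a second fluorine on this same carbon would give a step beyond the scatter. As far as these compounds go, a carbonyl in place of this carbon is equally open.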